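Trading a Fluorophenyl Group for a Small Cyclopropyl Ring

This account rests on a few compounds, and the source may have more. Where it says the series, first, only, none or still open, it means among the compounds named here.

In a functional assay on KYSE-70 cells for antiproliferative activity against KYSE-70 cell line (Homo sapiens), read by MTT assay, with a stated time of 72 h (a lower number here means a stronger inhibitor, a higher number a weaker inhibitor), compound 1 `O=C(c1ccnc2cc(Br)ccc12)N1CCCCC1` gives > 20000 nM as a limit of the test and not as a number. Compound 2 `COc1ccc2c(C(=O)Nc3cc(F)cc(F)c3)cc(=O)[nH]c2c1` likewise returns only a limit, with > 20000 nM as its reading. Compound 3 `O=C(Nc1cccc(F)c1)c1cc(=O)[nH]c2cc(-c3ccc(F)cc3)ccc12` gives 3300 nM in this assay and is the only one of the three with a true number.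

The next compound, compound 4 `O=C(Nc1cccc(F)c1)c1cc(=O)[nH]c2cc(C3CC3)ccc12`, differs from compound 3 at one place: cyclopropyl in place of 4-fluorophenyl on an aromatic carbon and the rest of the structure is unchanged.

Among the measured compounds shown here, no two measured compounds differ in one place only, so no measured step guides this change. The available hint is thin: of the three measured compounds, only compound 3 carries the 4-fluorophenyl group, and neither compound 1 nor compound 2 gives a number without it. Removing that group is therefore expected to weaken the compound beyond the usual scatter, and the reading may even reach the limit of the test. The expected change is a 3.6-fold higher number from compound 3 to compound 4 (0.56 log units; beyond the scatter) in this assay on this estimate. For compound 4 an expected 12000 nM (estimated range 4000 nM to 20000 nM) is the best estimate.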

Compound 4, half-maximal inhibitory concentration: > 20000 nM
Compound 4 was reported as a limit; the forecaster's own chance of this, stated with the estimate: 45%; middle value at least 1.6-fold (0.22 log units) from the limit.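

In this assay, among the compounds shown here, putting cyclopropyl in place of 4-fluorophenyl on this aromatic carbon gives an at least 6.0-fold higher number from compound 3 to compound 4 (0.78 log units; beyond the scatter), the first direct reading of this position from a change in one place only. Compound 3 keeps a measurable value while compound 4 does not, so on this shared core a small carbon ring at this place does not preserve what the 4-fluorophenyl group allows. The step gives only a minimum size, as the reading of compound 4 is a limit and not a number, and that limit is shared across the series: the limit of > 20000 nM in this assay, at which 3 of the 4 values shown sit.

The change swaps a six-membered aromatic ring of 7 heavy atoms, fluorine included, for a three-membered non-aromatic ring of 3 heavy atoms, so the compounds shown cannot tell whether the aromatic ring, the fluorine or simply the number of atoms matters. An unsubstituted phenyl ring on this carbon would separate the first two, while an amine or a longer carbon chain there would show whether anything other than an aromatic ring gives a measurable value.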